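A few compounds are considered here, and "the series" means these few. Any claim that something is new, unique, unknown or untested is made for them only; others in the source may bear on it.

Measured compounds in a functional assay on U-251 cells (Homo sapiens) for inhibition; on this read-out lower numbers stand for stronger inhibition of growth and higher numbers for weaker inhibition of growth:
- compound 1 `COc1cc(/C=C/C(=O)c2cccc(-n3cc(-c4ccc(Cl)cc4)[nH]c3=O)c2)cc(OC)c1OC`: 2120 nM
- compound 2 `COc1cc(/C=C/C(=O)c2cccc(-n3cc(-c4ccccc4)[nH]c3=O)c2)ccc1O`: 2110 nM
- compound 3 `O=C(/C=C/c1cccc(O)c1)c1cccc(-n2cc(-c3ccccc3)[nH]c2=O)c1`: 1610 nM

Compound 2 holds the second highest of the three numbers in this assay. Its nearest neighbour is compound 1, whose value sits at the same level, within the scatter. Among the compounds with values here, the one step that is computed in this set runs a 1.3-fold lower number from compound 2 to compound 3 (0.12 log units; within the scatter) and concerns the hydroxy-bearing ring on the double-bonded chain, not the ring on the shared core; it shows that set of three values lying on one plateau.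

Compound 4 `COc1ccc(-c2cn(-c3cccc(C(=O)/C=C/c4ccc(O)c(OC)c4)c3)c(=O)[nH]2)cc1` is the next member to be measured. It differs from compound 2 in one place: methoxy in place of hydrogen on an aromatic carbon. Within the data shown here, no measured step bears on this change directly. Compound 1 carries a chloro group on the same ring, but it also differs from compound 2 at the other aryl, so only its value can be set beside that of compound 2, and the two values are within the scatter of each other. Nothing in the set therefore points to a shift beyond the scatter for compound 4 in this assay. The step from compound 2 to compound 4 is expected to be a 1.1-fold lower number from compound 2 to compound 4 (0.02 log units; within the scatter). Compound 4 is estimated at 2000 nM, expected between 900 nM and 4500 nM.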

Compound 4, concentration for 50% growth inhibition: 3450 nM
Estimate against measurement, compound 4: 1.7-fold (0.24 log units) below, and the stated range covers the measured number.
By their numbers in this assay, from the lowest: compounds 3, 2, 1 and 4 (each within the scatter of the next, the first and the last beyond it).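

In this assay, within the data shown here, the change from phenyl to 4-methoxyphenyl gives a 1.6-fold higher number from compound 2 to compound 4 (0.21 log units; within the scatter) and is the first step read directly on this ring; the earlier compounds offered only the value of compound 1, which carries a chloro group there but also differs at the other aryl. A methoxy on this aromatic carbon, para to a large group, therefore leaves compound 4 on the same plateau as compound 2, with the two added heavy atoms producing no shift beyond the scatter. No further data bear on this result, so nothing can be said about what lies behind it.

From the compounds shown here alone, a single substituent does not define the position, and whether the flat response holds for an amine, a carboxylic acid or a longer chain such as butoxy on this carbon remains open. Also open, going by these compounds, is how a chloro group alone would read against compound 2 with the 4-hydroxy-3-methoxyphenyl side kept in place, as compound 1 changes both ends of the molecule.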